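A few compounds are considered here, and "the series" means these few. Any claim that something is new, unique, unknown or untested is made for them only; others in the source may bear on it.

Measured compounds:
- compound 1 `Cc1ccc(C(=O)N/N=C/c2cc(I)cc(I)c2O)cc1`: > 25000 nM
- compound 2 `O=C(N/N=C/c1cc(I)cc(I)c1O)c1ccc(Cl)cc1`: 14800 nM
- compound 3 `CC(C)(C)c1ccc(C(=O)N/N=C/c2cc(I)c(O)c(I)c2)cc1`: 45900 nM

These three share a core and differ in the group on the outer benzene ring. In a functional assay on HepG2 cells (Homo sapiens) for cytotoxicity, with a stated time of 24 h (a higher number here means a weaker inhibitor, a lower number a stronger inhibitor), compound 1 sits at a limit of the assay, (the limit of > 25000 nM in this assay, at which 1 of the 3 values shown sits), not at a measured number. Compound 3 holds the highest of the two real numbers; the nearest, compound 2, lies lower by a gap beyond the usual scatter.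

Going by the values given here, the only step measured between neighbours is an at least 1.6-fold lower number from compound 1 to compound 2 (0.22 log units; that floor lies within the scatter), a swap of one small group on that same aromatic carbon, and its floor lies within the scatter. Compound 4 `O=C(N/N=C/c1cc(I)c(O)c(I)c1)c1ccc(C(F)(F)F)cc1` is not yet measured; it arises from compound 3 by trifluoromethyl in place of tert-butyl on an aromatic carbon. That earlier step is the one that bears on this change, and it was small, so no step beyond the scatter is expected in this assay, in either direction. Compound 4 is therefore estimated at 40000 nM, between 15000 nM and 110000 nM, meaning an expected step of a 1.1-fold lower number from compound 3 to compound 4 (0.06 log units; within the scatter).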

Compound 4, half-maximal inhibitory concentration: 57400 nM
Beside the measured number, compound 4's estimate is 1.4-fold (0.16 log units) below it, within the range that was stated.
By their numbers in this assay, from the lowest: compound 2; then compounds 3 and 4 (each within the scatter of the next).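

Going by these compounds alone, this is the first step here with a real number at both ends, as the earlier step had only a floor. In this assay, putting trifluoromethyl in place of tert-butyl gives a 1.3-fold higher number from compound 3 to compound 4 (0.10 log units; within the scatter), so compounds 3 and 4 cannot be told apart, although the entering group has fluorine where the leaving group has carbon. At this aromatic carbon, para to a large group, the assay therefore separates neither of these two groups from the other, and nothing measured here explains that.

From the compounds shown here alone, it remains open whether an amine or a carboxylic acid on this same carbon would shift the number beyond the scatter. A longer chain, such as n-hexyl, is equally untested among the compounds shown, so how far this position tolerates change remains unknown.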